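Shortening the Carbamate Chain: Heptyl to Ethyl

The compounds below may be only part of what the source reports. "The series", "measured", "known", "first", "only" and "open" are said of these compounds alone.

Compound 1 `CCCCCCCOC(=O)Nc1ccccc1` holds the higher of the two recorded numbers, giving 32.5% in a functional assay on the whole organism with Mus musculus as the target, in the forced swim test, with stated times of 1 h and 5 min, at a dose of 10 mg/kg; a higher number here means more inhibition at the dose given (going by the name of the read-out), a lower number less inhibition. Compound 2 `O=C(Nc1ccccc1)N1CCN(c2ccccc2)CC1` gives 27.7% in this assay, a gap that lies within the usual scatter, leaving the two indistinguishable. Compound 3 `CCOC(=O)Nc1ccccc1` is not yet measured. It differs from compound 1 in one place: hydrogen in place of pentyl on a saturated chain carbon, two bonds along the chain from an oxygen next to a carbonyl group. Among the measured compounds shown here, no measured pair shows this change, and nothing in the data fixes its size or direction. A small drop, or none beyond the scatter, is expected. The step of a number 7.5 percentage points lower from compound 1 to compound 3 (within the scatter) is expected to be modest. Compound 3 is estimated at 25%, ranging from 8% to 40%.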

Compound 3, a percentage reported as inhibition, in the whole organism at one dose (the size of the read-out at that dose, not a potency): 21.6%
Compound 3: middle estimate off by 3.4 percentage points, on the high side; the measured number falls inside the stated range.
By their numbers in this assay, from the lowest: compounds 3, 2 and 1 (each within the scatter of the next, the first and the last beyond it).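

Among the compounds shown here, putting hydrogen in place of pentyl on this saturated chain carbon gives the first measured step at this position: in this assay the read-out is a number 10.9 percentage points lower from compound 1 to compound 3 (beyond the scatter) for this change. The pentyl part of the chain therefore matters to this read-out, although the step is modest. No measurement shown here explains the drop.

Going by these compounds, what a butyl chain, a chain longer than heptyl or an amine at this place would give remains open. So does whether the read-out follows chain length steadily or changes abruptly.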